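The source may hold more compounds than are shown below. What is called first, only, known or untested is meant among the compounds shown, and "the series" means these compounds.

Measured compounds:
compound 1 `O=C(O)C1=Cc2ccccc2OC1(OCc1cc(-c2ccc(F)cc2)no1)C(F)(F)F` in a functional assay on MCF7 cells (Homo sapiens) for inhibition, read by MTT assay, with a stated time of 24 h; a lower number here means a stronger inhibitor, a higher number a weaker inhibitor: 64200 nM
compound 2 `CCOC(=O)C1=Cc2ccccc2OC1(OCc1cn(CC(=O)Nc2ccccc2F)nn1)C(F)(F)F` in this assay: 42100 nM
compound 3 `CCOC(=O)C1=Cc2ccccc2OC1(OCc1cc(-c2ccc(Br)cc2)no1)C(F)(F)F` in this assay: > 150000 nM, a limit of the assay rather than a number

Compound 2 holds the lowest of the two numbers recorded, with compound 1 close enough that the gap lies within the scatter, so neither is placed ahead of the other. Compound 3 sits at the limit of > 150000 nM in this assay, at which 1 of the 3 values shown sits, and gives no number. Compound 4 `CCOC(=O)C1=Cc2ccccc2OC1(OCc1cn(-c2ccc([N+](=O)[O-])cc2)nn1)C(F)(F)F` differs from compound 2 in a single place: 4-nitrophenyl in place of ((2-fluorophenyl)carbamoyl)methyl on an aromatic nitrogen. Among the compounds with values here, no step between measured compounds is available, so the expectation for compound 4 rests on compound 2 alone; the step of a 1.4-fold higher number from compound 2 to compound 4 (0.15 log units; within the scatter) is expected to stay within the scatter or run slightly weaker. Compound 4 is therefore estimated at 60000 nM, between 20000 nM and 180000 nM, with a real chance that only a limit is reported.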

Compound 4, half-maximal inhibitory concentration: > 150000 nM
Compound 4: no number, only a limit; the forecaster's own chance of this, stated with the estimate: 35%; middle value at least 2.5-fold (0.39 log units) from the limit.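

On the aromatic nitrogen of the five-membered ring, 4-nitrophenyl in place of ((2-fluorophenyl)carbamoyl)methyl gives an at least 3.5-fold higher number from compound 2 to compound 4 (0.55 log units; beyond the scatter) in this assay, so this position does respond to the group it carries. The value of compound 4 is a limit and not a number, so the step has a lower bound only: the limit of > 150000 nM in this assay, at which 2 of the 4 values shown sit.

This single pair does not separate the amide hydrogen, the chain and the nitro group from one another. A plain phenyl or a 4-aminophenyl on that nitrogen would help to tell them apart.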